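Replacing the Hydroxyphenyl Thioester with an Acetyl Group

The source may report more compounds than this note shows. Statements on the series, on what has been measured and on what is new or still open speak of the compounds shown alone.

Measured so far:
compound 1 `O=C(S[C@@]12CC[C@H](O)[C@@H]1C(=O)NC2=O)c1ccc(O)cc1`: 71800 nM
compound 2 `O=C(S[C@]12CC[C@@H](O)[C@H]1C(=O)NC2=O)c1ccc(O)cc1`: 42000 nM
compound 3 `O=C(S[C@@]12CC[C@@H](O)[C@@H]1C(=O)NC2=O)c1ccc(O)cc1`: 127000 nM

In a functional assay on RAW264.7 cells (Mus musculus) for inhibition, read by Griess assay, with a stated time of 24 h (on this read-out higher numbers stand for weaker inhibition and lower numbers for stronger inhibition), compound 1 gives 71800 nM, a number that lies between those of the other two compounds measured. The nearest is compound 2, with a 1.7-fold lower number from compound 1 to compound 2 (0.23 log units; within the scatter); the step to compound 3 is a 1.8-fold higher number from compound 1 to compound 3 (0.25 log units; within the scatter). Neither of these counts as a real difference. Within the data shown here, the only step that does is a 3.0-fold higher number from compound 2 to compound 3 (0.48 log units; beyond the scatter). All three compounds share the same atoms and bonds and differ only in how their stereocentres are drawn (the fact that compounds 1 and 2 differ only in the configuration as drawn, (the fact that compounds 1 and 3 differ only in the configuration as drawn), (the fact that compounds 2 and 3 differ only in the configuration as drawn)), so the measured steps speak only about configuration.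

Compound 4 `CC(=O)S[C@@]12CC[C@H](O)[C@@H]1C(=O)NC2=O` departs from compound 1 in a different way: methyl in place of 4-hydroxyphenyl on a carbonyl carbon. Among the measured compounds shown here, no measured step bears on this change, since none of them alters the group on the carbonyl carbon attached to sulfur. The expectation for compound 4 therefore rests on compound 1 alone, with a wide margin. The expected step is a 1.8-fold higher number from compound 1 to compound 4 (0.26 log units; within the scatter), leaning toward a somewhat higher number. The estimate for compound 4 in this assay is 130000 nM, within a range from 40000 nM to 400000 nM.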

Compound 4, half-maximal inhibitory concentration: 148000 nM
The estimate for compound 4 lay 1.1-fold (0.06 log units) below the measured number, within the range that was stated.
By their numbers in this assay, from the lowest: compounds 2, 1, 3 and 4 (each within the scatter of the next, the first and the last beyond it).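

Among these compounds, this is the first measured change to the group on the carbonyl carbon attached to sulfur, and unlike the configuration changes, it alters the atoms themselves. In this assay, methyl in place of 4-hydroxyphenyl gives a 2.1-fold higher number from compound 1 to compound 4 (0.31 log units; beyond the scatter), so losing the whole aromatic ring weakens inhibition only modestly and compound 4 still gives a measurable number. Nothing available explains why this change shifts the number.

The compounds shown cannot separate the loss of the ring from the loss of its hydroxyl, and a plain phenyl group or a longer chain such as propyl on the same carbonyl carbon would help to tell these apart. Going by these compounds, it also remains open whether the same exchange has a similar effect on the configurations of compound 2 and compound 3.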